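The compounds below may be only part of what the source reports. "The series", "measured", "known", "first", "only" and "open" are said of these compounds alone.

Measured compounds and their values:
- compound 1, `N#Cc1ccc(Nc2nccc(Nc3ccc(-c4ccc(C#N)cc4)c(F)c3)n2)cc1`: in a functional assay on MT4 cells (Homo sapiens) for cytotoxicity, read by MTT assay, with a stated time of 5 days (a higher number here means that more compound is tolerated, a lower number that less compound is tolerated), compound 1 reaches only the limit > 271000 nM.
- compound 2, `Cc1cc(Nc2ccnc(Nc3ccc(C#N)cc3)n2)ccc1-c1ccc(C#N)cc1`: in this assay compound 2 gives 12400 nM.
- compound 3, `Cc1cc(-c2ccc(C#N)cc2F)ccc1Oc1ccnc(Nc2ccc(C#N)cc2)n1`: in this assay compound 3 reaches only the limit > 296000 nM.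

Compound 2 and compound 1 differ in one place, (fluoro in place of methyl on an aromatic carbon), and the step is an at least 21-fold higher number from compound 2 to compound 1 (1.33 log units; beyond the scatter); the size of that step is bounded because compound 1 sits at the limit of > 271000 nM in this assay, at which 1 of the 3 values shown sits. Compound 3 likewise sits at the limit of > 296000 nM in this assay, at which 1 of the 3 values shown sits. How the core of compound 3 differs from the core of compound 2 is not broken down here.

Compound 4, `N#Cc1ccc(Nc2nccc(Oc3ccc(-c4ccc(C#N)cc4F)cc3F)n2)cc1`, is not yet measured. It differs from compound 3 by fluoro in place of methyl on an aromatic carbon. Within the data shown here, this is the same kind of change as the one from compound 2 to compound 1, but not the same: there the place was ortho to a 4-cyanophenyl group and meta to a large group, here it is ortho to a large group and meta to a 4-cyano-2-fluorophenyl group. Compound 4 is expected to give 300000 nM, between 150000 nM and 600000 nM, most likely again as a limit. The expected step is a step that the limit leaves unreadable from compound 3 to compound 4, resting on compound 3 already standing at the limit of > 296000 nM in this assay, at which 1 of the 3 values shown sits.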

Compound 4, half-maximal cytotoxic concentration: > 294000 nM
Compound 4: only a limit was reported; the forecaster's own chance of this, stated with the estimate: 80%; the middle value is on the limit's open side.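

In this assay compound 4 reaches only the limit > 294000 nM. Compound 3 also stands at a limit, so no step can be read between compound 3 and compound 4. The compounds shown leave open whether fluoro in place of methyl changes the value at this place at all, as it does from compound 2 to compound 1.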